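Taking a Methyl Off a Ring Carbon at the Limit

This account rests on a few compounds, and the source may have more. Where it says the series, first, only, none or still open, it means among the compounds named here.

In an ADME assay on MRC5 cells (Homo sapiens) for cytotoxicity, read by resazurin assay, with a stated time of 72 h (on this read-out lower numbers stand for stronger inhibition and higher numbers for weaker inhibition), compound 2 (`CC1(COc2cccc(-c3ccc(F)nc3)n2)CCn2cc([N+](=O)[O-])nc2O1`) gives > 64000 nM, which is a limit of the assay and not a number. Compound 3 (`CC1(COc2cccc(-c3ccc(F)cc3F)n2)CCn2cc([N+](=O)[O-])nc2O1`) gives > 64000 nM, also a limit. Compound 1 (`O=[N+]([O-])c1cn2c(n1)OC(COc1cccc(-c3ccc(F)nc3F)n1)CC2`) gives > 64000 nM, again a limit. Compound 2 therefore has no exact position, and the whole picture so far is the limit of > 64000 nM in this assay, at which 3 of the 3 values shown sit.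

Compound 4 (`O=[N+]([O-])c1cn2c(n1)OC(COc1cccc(-c3ccc(F)nc3)n1)CC2`) comes from compound 2 by a single change: hydrogen in place of methyl on a saturated ring carbon. In words, this is hydrogen in place of methyl on a saturated ring carbon.

Within the data shown here, the only measured step is a step that the two limits leave unreadable from compound 2 to compound 3, so it offers no size to carry over, and it lies at a different place in the structure. With no readable step to draw on, a change beyond the usual scatter is not expected in this assay, in either direction. The expected step is a number no higher from compound 2 to compound 4 (the limit leaves the size open).

Compound 4 is estimated at 64000 nM, with an expected range of 35000 nM to 120000 nM.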

Compound 4, half-maximal inhibitory concentration: 35000 nM
Beside the measured number, compound 4's estimate is 1.8-fold (0.26 log units) above it; the measured number falls inside the stated range.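

Among these compounds, compound 4 is the first compound here with a real number in this assay instead of a limit, so this ring carbon now yields a step with a floor: hydrogen in place of methyl gives an at least 1.8-fold lower number from compound 2 to compound 4 (0.26 log units; that floor lies within the scatter). Hydrogen in place of fluoro on an aromatic carbon gives an at least 1.8-fold lower number from compound 1 to compound 4 (0.26 log units; that floor lies within the scatter), so the same number also puts a floor under a change elsewhere in the molecule. Both are only floors that stay within the scatter, so neither change is shown to shift the number, and most of the picture remains at the ceiling: the limit of > 64000 nM in this assay, at which 3 of the 4 values shown sit.

Going by these compounds, the true size of either step stays open, and the step between the two methyl compounds cannot be read. Also open, on these data alone, is what an ethyl group or an amine on this ring carbon would do to the number.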